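Urea series with triazolyl nitrogen: cyano in place of ethyl

The source may report more compounds than this note shows. Statements on the series, on what has been measured and on what is new or still open speak of the compounds shown alone.

Measured so far:
compound 1 `COc1ccc(CN(C(=O)Nc2ccc(C#N)cc2)n2cnnc2)cc1OC`: > 50000 nM
compound 2 `CCc1ccc(NC(=O)N(Cc2cc(OC)c(OC)c(OC)c2)n2cnnc2)cc1`: 24800 nM
compound 3 `CCCCCCCCCNC(=O)N(Cc1cc(OC)ccc1OC)n1cnnc1`: > 50000 nM

Among the compounds with values here, in a functional assay on MDA-MB-231 cells (Homo sapiens) for cytotoxicity, read by MTT assay, with a stated time of 48 h (on this read-out higher numbers stand for weaker inhibition and lower numbers for stronger inhibition), compound 2 gives 24800 nM, the only plain number among the three measured compounds. For compound 1 this assay returns only a limit, > 50000 nM. Compound 3 likewise sits at a limit, > 50000 nM. Within the data shown here, two of the three values therefore sit at the same limit (the limit of > 50000 nM in this assay, at which 2 of the 3 values shown sit), and no single-point step between measured compounds is available to calibrate the change considered here.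

Compound 4 `COc1cc(CN(C(=O)Nc2ccc(C#N)cc2)n2cnnc2)cc(OC)c1OC` is not yet measured. It differs from compound 2 in one place: cyano in place of ethyl on an aromatic carbon, turning (4-ethylphenyl)amino into (4-cyanophenyl)amino on the urea. Compound 1 already carries the (4-cyanophenyl)amino group and gives only a limit (the limit of > 50000 nM in this assay, at which 2 of the 3 values shown sit), so the step from compound 2 to compound 4 is expected to go toward weaker inhibition, with a 1.8-fold higher number from compound 2 to compound 4 (0.26 log units; within the scatter) as the expected size, and a fair chance that this assay again reports only a limit. The estimate for compound 4 is 45000 nM, with a range from 15000 nM to 150000 nM.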

Compound 4, half-maximal inhibitory concentration: > 50000 nM
Compound 4: a limit, no number (the forecaster's own chance of this, stated with the estimate: 55%); middle value at least 1.1-fold (0.04 log units) from the limit.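

In this assay, within the data shown here, cyano in place of ethyl on the aromatic carbon para to a large group gives an at least 2.0-fold higher number from compound 2 to compound 4 (0.30 log units; that floor lies within the scatter), the first direct reading of this change, and that reading is only a floor. The step for methoxy in place of hydrogen on an aromatic carbon, which joins the two cyano compounds, cannot be read, as both of their values are limits. Compound 2 stays the only compound in the series with a plain number: the limit of > 50000 nM in this assay, at which 3 of the 4 values shown sit.

From the compounds shown here alone, how far past the limit compound 4 lies stays unknown, so the size of the change from ethyl to cyano is fixed from one side only. Going by these compounds, whether an amine, a carboxylic acid or a longer chain in place of ethyl would give a plain number also stays open.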